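A phenyl group enters at the sulfonyl sulfur

The compounds below may be only part of what the source reports. "The series", "measured", "known", "first", "only" and "open" are said of these compounds alone.

Compound 2 `O=C(Nc1ccc(S(=O)(=O)C2=CCOC=C2)cc1)c1ccc([N+](=O)[O-])o1` was tested in an ADME assay on IMR-90 cells (Homo sapiens) for cytotoxicity, read by CellTiter-Blue, with a stated time of 46 h (on this read-out lower numbers stand for an effect already at smaller amounts and higher numbers for an effect only at larger amounts of compound), and gave > 25000 nM, which is a limit of the assay rather than a number. Compound 1 `CC(C)(C)C1CCN(S(=O)(=O)c2ccc(NC(=O)c3ccc([N+](=O)[O-])o3)cc2)CC1` gave > 25000 nM in this assay, also a limit. Among the measured compounds shown here, the step that the two limits leave unreadable from compound 1 to compound 2 therefore cannot be sized, and the only evidence on the measured pair is the limit of > 25000 nM in this assay, at which 2 of the 2 values shown sit. Compound 3 `O=C(Nc1ccc(S(=O)(=O)c2ccccc2)cc1)c1ccc([N+](=O)[O-])o1` is the next variation; it differs from compound 2 by a group of 6 heavy atoms (6 carbon; one six-membered aromatic ring of carbon only) in place of a group of 6 heavy atoms (5 carbon, 1 oxygen; one six-membered non-aromatic ring with 1 hetero atom), on a sulfonyl sulfur. No measured step shows a readable change, so nothing indicates a shift beyond the scatter in this assay, and compound 2 stands where both shown values sit, at the limit. Compound 3 is expected to remain in the same region, with an estimated step that the limit leaves unreadable from compound 2 to compound 3 that is none beyond the scatter. The estimate for compound 3 in this assay is 40000 nM, expected to lie between 15000 nM and 120000 nM.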

Compound 3, half-maximal effective concentration: > 25000 nM
Compound 3 was reported as a limit (the forecaster's own chance of this, stated with the estimate: 80%); the middle value is on the limit's open side.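

Compound 1, compound 2 and compound 3 are all reported as limits of the assay in this assay, so no step among them can be read: the limit of > 25000 nM in this assay, at which 3 of the 3 values shown sit.

The compounds shown leave open how far apart the three lie, and whether any group on the sulfonyl sulfur gives a measurable value in this assay.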